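Lengthening the chain on the ring nitrogen of compound 1

The source may report more compounds than this note shows. Statements on the series, on what has been measured and on what is new or still open speak of the compounds shown alone.

Compound 1 `O=C(NO)c1ccc(-c2cn([C@H]3C[C@@H](CO)N(Cc4ccccc4)C3)nn2)cc1` is the starting point. In an assay on Sf9 cells for inhibition of histone deacetylase 11 (Homo sapiens), read by fluorescence, tested at 0.5 uM (a lower number here means less inhibition, a higher number more inhibition at the concentration tested (going by the name of the read-out)), compound 1 gives < 10%, which is a limit of the assay and not a number. Compound 2 `O=C(NO)c1ccc(-c2cn([C@@H]3C[C@@H](CO)N(Cc4ccccc4)C3)nn2)cc1` has the same atoms and bonds and differs only in configuration as drawn. In this assay compound 2 gives < 10%, again a limit rather than a number. The step that the two limits leave unreadable from compound 1 to compound 2 therefore cannot be read, given the limit of < 10% in this assay, at which 2 of the 2 values shown sit, and (the fact that compounds 1 and 2 differ only in the configuration as drawn). Compound 3 `O=C(NO)c1ccc(-c2cn([C@H]3C[C@@H](CO)N(CCCc4ccccc4)C3)nn2)cc1` has not yet been measured; it differs from compound 1 by phenethyl in place of phenyl on a saturated chain carbon bound to an amine nitrogen in a ring. Among the compounds with values here, no measured step speaks to this change, and the single measured step is unreadable, so there is nothing to point in either direction. Compound 3 is accordingly expected to stay in the low range in this assay, estimated at 6% within 0% to 18%. The step that the limit leaves unreadable from compound 1 to compound 3 is expected to be none beyond the scatter.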

Compound 3, a percentage reported as inhibition, at one concentration (the size of the read-out at that concentration, not a potency): < 10%
Compound 3 ended at the assay's limit; the forecaster's own chance of this, stated with the estimate: 70%; the middle value does not contradict the limit.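

The step from compound 1 to compound 3 cannot be read, because both compounds sit at a limit of the assay: the limit of < 10% in this assay, at which 3 of the 3 values shown sit.

The compounds shown leave open whether going from benzyl to 3-phenylpropyl changes inhibition at all in this assay, and whether any change on the shared core would give a readable value.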